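A few compounds are considered here, and "the series" means these few. Any claim that something is new, unique, unknown or untested is made for them only; others in the source may bear on it.

Of the compounds shown here, three of a shared core have been tested in a functional assay on PANC-1 cells (Homo sapiens) for inhibition, read by MTT assay, with a stated time of 24 h, tested at 10 uM; on this read-out lower numbers stand for less inhibition and higher numbers for more inhibition at the one concentration tested (going by the name of the read-out). Compound 1 `CC(C)=CCC1Cc2c(OCCCNS(=O)(=O)c3ccc(Cl)cc3)cc(=O)n(CCCO)c2CC1(C)C` gives 24.7%, compound 2 `CCOc1cc(=O)n(CCCO)c2c1CC(C/C=C(\C)CCC=C(C)C)C(C)(C)C2` gives 67.8%, and compound 3 `CC(C)=CCC/C(C)=C/CC1Cc2c(OCCCNS(=O)(=O)c3ccc(Cl)cc3)cc(=O)n(CCCO)c2CC1(C)C` gives 14.5%. Compound 3 stands lowest of the three: it sits a number 10.2 percentage points lower from compound 1 to compound 3 (beyond the scatter) and a number 53.3 percentage points lower from compound 2 to compound 3 (beyond the scatter).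

Compound 4 `COc1ccc(C(=O)NCCCOc2cc(=O)n(CCCO)c3c2CC(C/C=C(\C)CCC=C(C)C)C(C)(C)C3)cc1` differs from compound 3 in one place: (4-methoxyphenyl)carbonyl in place of (4-chlorophenyl)sulfonyl on an amine nitrogen. Among the measured compounds shown here, no measured step covers this exchange. For the measured compounds named here, the only step that touches the same arm is the one from compound 2 to compound 3, in which the whole arm appears and brings the large fall already given; that step says the arm as a whole costs inhibition, but not how a carbonyl in place of a sulfonyl would alter it. The step from compound 1 to compound 3 concerns a different part of the molecule and does not bear on it.

Going by the values given here, with no guiding step, the expectation for compound 4 is a small rise in this assay, a number 10.5 percentage points higher from compound 3 to compound 4 (beyond the scatter), that may not exceed the scatter. Compound 4 is therefore estimated at 25%, expected to lie between 8% and 50%.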

Compound 4, a percentage reported as inhibition, at one concentration (the size of the read-out at that concentration, not a potency): 45.7%
Estimate against measurement, compound 4: 20.7 percentage points below, within the range that was stated.
By their numbers in this assay, from the lowest: compound 3; then compound 1; then compound 4; then compound 2.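

In this assay, the group on the amine nitrogen clearly matters: (4-methoxyphenyl)carbonyl in place of (4-chlorophenyl)sulfonyl gives a clear recovery (a number 31.2 percentage points higher from compound 3 to compound 4 (beyond the scatter)), so the loss seen when the arm was added depends on what the arm carries. Adding the arm that ends in the carbonyl group still costs inhibition (a number 22.1 percentage points lower from compound 2 to compound 4 (beyond the scatter)), but the fall is smaller than with the sulfonyl arm (a number 53.3 percentage points lower from compound 2 to compound 3 (beyond the scatter)). No measured evidence is available to explain this difference.

The exchange alters the linking group and the ring substituent together, so the compounds shown cannot separate the carbonyl from the methoxy. A (4-chlorophenyl)carbonyl group or a (4-methoxyphenyl)sulfonyl group on the same nitrogen would tell those two changes apart.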